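The compounds below may be only part of what the source reports. "The series", "measured", "known", "first", "only" and "open" are said of these compounds alone.

Compound 2 `CNC(=O)N1CCCc2ccc(NC(=O)c3cccc(-c4cn[nH]c4)c3)cc21` is the stronger of the two compounds measured in a functional assay on MV4-11 cells (Homo sapiens) for antiproliferative activity, with a stated time of 6 days, tested at 1.56 uM; on this read-out higher numbers stand for a stronger effect at the one concentration tested and lower numbers for a weaker effect. In this assay, for the measured compounds named here, compound 2 gives 27.9%, while its only neighbour, compound 1 `CNC(=O)N1CCCc2ccc(NC(=O)c3cccc(-c4ccccc4)c3)cc21`, gives 2.83%. Going by the values given here, the one measured step is a number 25.1 percentage points higher from compound 1 to compound 2 (beyond the scatter), and it is the sole guide available here. Compound 3 `CNC(=O)N1CCCc2ccc(NC(=O)c3cccc(-c4ccn(S(C)(=O)=O)n4)c3)cc21` has not yet been tested. It differs from compound 2 in one place: 1-(methylsulfonyl)-1H-pyrazol-3-yl in place of 1H-pyrazol-4-yl on an aromatic carbon The step from compound 1 to compound 2 bears on this change only loosely: it shows that the ring at this position can move the number, yet nothing measured tells what a 1-(methylsulfonyl)-1H-pyrazol-3-yl group will do. Given the swing seen from compound 1 to compound 2, a step from compound 2 to compound 3 of a number 15.9 percentage points lower from compound 2 to compound 3 (beyond the scatter) is expected, pointing downward but with wide uncertainty. For compound 3 an inhibition of 12% is estimated, within -5% to 35%.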

Compound 3, a percentage reported as inhibition, at one concentration (the size of the read-out at that concentration, not a potency): 4.03%
For compound 3 the middle estimate is 8 percentage points above the measured one; the measured number falls inside the stated range.
By their numbers in this assay, from the lowest: compounds 1 and 3 (each within the scatter of the next); then compound 2.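

A pyrazole ring at this position does not by itself carry the gain seen with compound 2: the change to 1-(methylsulfonyl)-1H-pyrazol-3-yl gives a number 23.9 percentage points lower from compound 2 to compound 3 (beyond the scatter) in this assay, while the step against the phenyl group is a number 1.2 percentage points higher from compound 1 to compound 3 (within the scatter). Of the three groups tested, only 1H-pyrazol-4-yl stands apart, and it is also the only one of the two pyrazoles with a hydrogen-bond donor, although this link rests on a single pair. No measurement explains the drop.

This change alters the ring's point of attachment and adds the methylsulfonyl group at once, so the two contributions cannot be separated. 1H-pyrazol-3-yl and 1-methyl-1H-pyrazol-4-yl, each differing from compound 2 in only one of these respects, would help to tell them apart.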